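From fluoro to methoxy on the benzyl amide

The source may hold more compounds than are shown below. What is called first, only, known or untested is meant among the compounds shown, and "the series" means these compounds.

Measured in a functional assay on HCT-116 cells (Homo sapiens) for cytotoxicity, read by MTT assay, with a stated time of 72 h; on this read-out higher numbers stand for weaker inhibition and lower numbers for stronger inhibition:
compound 1 `N[C@H]1CC[C@H](Nc2c(C(=O)NCc3ccco3)nc(Br)c3cccnc23)CC1`: > 10000 nM
compound 2 `N[C@H]1CC[C@H](Nc2c(C(=O)NCc3ccc(Oc4ccccc4)cc3)nc(Br)c3cccnc23)CC1`: "not determined" (no result reported)
compound 3 `N[C@H]1CC[C@H](Nc2c(C(=O)NCc3ccc(F)cc3)nc(Br)c3cccnc23)CC1`: 7000 nM

Compound 1 shows > 10000 nM and this entry is a limit of the assay and not a number. Compound 2 gave no result. For the measured compounds named here, compound 3 therefore stands alone at 7000 nM as the only actual number in the set.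

Compound 4 `COc1ccc(CNC(=O)c2nc(Br)c3cccnc3c2N[C@H]2CC[C@H](N)CC2)cc1` keeps the shared core of compound 3 and alters one group (methoxy in place of fluoro on an aromatic carbon): methoxy in place of fluoro on an aromatic carbon, para to a large group. Going by the values given here, only one measured step bears on this, and only loosely. That step (an at least 1.4-fold lower number from compound 1 to compound 3 (0.15 log units; that floor lies within the scatter)) replaces a different group on the same side chain, and it starts from a limit. Among the compounds with values here, no measured step exchanges fluoro for another group on this aromatic ring, so the data point in neither direction. The expectation thus stays close to compound 3 (7000 nM), and the step expected in this assay (no change at the digits printed from compound 3 to compound 4 (within the scatter)) is none beyond the scatter. A result for compound 4 may also come back only as a limit (the limit of > 10000 nM in this assay, at which 1 of the 3 values shown sits). The estimate for compound 4 is an expected 7000 nM (expected range 3000 nM to 14000 nM).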

Compound 4, half-maximal inhibitory concentration: 3000 nM
For compound 4 the middle estimate is 2.3-fold (0.37 log units) above the measured one, and the stated range covers the measured number.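

In this assay, for the compounds shown here, the exchange of fluoro for methoxy is the first measured change on this aromatic ring, at the carbon para to a large group, and it reads a 2.3-fold lower number from compound 3 to compound 4 (0.37 log units; beyond the scatter), so the group at this place does affect the read-out. Compound 1 stands at > 10000 nM, which is a limit of the assay and not a number. Against that limit, the earlier exchange of furan-2-yl for 4-fluorophenyl gave an at least 1.4-fold lower number from compound 1 to compound 3 (0.15 log units; that floor lies within the scatter), whereas the exchange for 4-methoxyphenyl gives an at least 3.3-fold lower number from compound 1 to compound 4 (0.52 log units; beyond the scatter), so a benzyl amide now separates from the furan-2-yl amide by more than the scatter.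

On these data alone, a single pair on this ring gives no trend, and even compound 4 remains a weak cytotoxic agent in this assay, so it stays open whether a hydroxy group, a chlorine atom, an ethoxy group or a dimethylamino group at the same carbon would lower the number further. The true size of any step that starts from compound 1 also stays open, since that end of the comparison remains capped: the limit of > 10000 nM in this assay, at which 1 of the 4 values shown sits.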